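From benzylamino to (4-ethylphenyl)amino on a shared core

The source may report more compounds than this note shows. Statements on the series, on what has been measured and on what is new or still open speak of the compounds shown alone.

In a functional assay on ECa-109 cells for inhibition, with ECa-109 cell line (Homo sapiens) as the target, read by sulforhodamine B assay (a higher number here means a weaker inhibitor, a lower number a stronger inhibitor), compound 1 `O=C1C=C(NCc2ccccc2)C(=O)c2c1nc1n2[C@H]2OC[C@@H](O)[C@H]2OC1` gives > 8000 nM as a limit, not a number. Compound 2 `COc1ccccc1NC1=CC(=O)c2c(nc3n2[C@H]2OC[C@@H](O)[C@H]2OC3)C1=O` gives > 4000 nM as a limit too. Among the compounds with values here, compound 1 therefore stands without an exact value, and no measured step is available as a guide. Compound 3 `CCc1ccc(NC2=CC(=O)c3nc4n(c3C2=O)[C@H]2OC[C@@H](O)[C@H]2OC4)cc1` keeps the shared core but carries 4-ethylphenyl in place of benzyl on an amine nitrogen. A modest expected move toward stronger inhibition in this assay is all that is estimated (an at least 2.0-fold lower number from compound 1 to compound 3 (0.30 log units; that floor lies within the scatter)). Compound 3 is estimated at 4000 nM with an expected range from 1000 nM to 12000 nM if a number is reported at all.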

Compound 3, half-maximal inhibitory concentration: 3080 nM
Estimate against measurement, compound 3: 1.3-fold (0.11 log units) above; the range from low to high includes it.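

Within the data shown here, on the amine nitrogen of the shared core, 4-ethylphenyl in place of benzyl brings the first exact number in this assay, with compound 3 at 3080 nM and an at least 2.5-fold lower number from compound 1 to compound 3 (0.41 log units; beyond the scatter). Compound 1 has only a limit, so this step is a floor and its full size stays unknown: the limit of > 8000 nM in this assay, at which 1 of the 3 values shown sits.

The compounds shown do not separate the effect of the ethyl group from that of attaching the ring directly to the nitrogen, as plain phenyl would. Going by these compounds, how a longer chain in place of ethyl, or a carboxylic acid on that ring, would read also remains open.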